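This account rests on a few compounds, and the source may have more. Where it says the series, first, only, none or still open, it means among the compounds named here.

In a functional assay on HCT-116 cells (Homo sapiens) for cytotoxicity, read by MTT assay, with a stated time of 48 h, in the presence of a further agent that is not named here (on this read-out lower numbers stand for an effect already at smaller amounts and higher numbers for an effect only at larger amounts of compound), compound 1 (`COc1ccc(-c2cc(NNC(=O)Nc3cc(Cl)nc(Cl)c3)nc3c2cnn3C)cc1`) gives 12300 nM as the lowest number, while compound 2 (`COc1ccc(-c2cc(NNC(=O)Nc3cc(Cl)nc(OC(C)C)c3)nc3c2cnn3C)cc1`) gives 39800 nM and compound 3 (`CCCCOc1cc(NC(=O)NNc2cc(-c3ccc(OC)cc3)c3cnn(C)c3n2)cc(Cl)n1`) gives 36500 nM. Compound 3 therefore sits with compound 2 at the upper end of this small set and clearly apart from compound 1.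

Compound 4 (`CCCOc1cc(NC(=O)NNc2cc(-c3ccc(OC)cc3)c3cnn(C)c3n2)cc(Cl)n1`) differs from compound 3 by hydrogen in place of methyl on a saturated chain carbon, three bonds along the chain from an oxygen on an aromatic ring (butyl to propyl, on the oxygen on the aromatic ring).

The closest measured change is on that same oxygen (a 1.1-fold lower number from compound 2 to compound 3 (0.04 log units; within the scatter)), and it stays within the scatter. Replacing chloro with isopropoxy (a 3.2-fold higher number from compound 1 to compound 2 (0.51 log units; beyond the scatter)) or with butoxy (a 3.0-fold higher number from compound 1 to compound 3 (0.47 log units; beyond the scatter)) gave modest steps of similar size. Compound 4 keeps an oxygen-linked chain in that place, so no step beyond the scatter is expected in this assay. No propyl chain has been measured, so this expectation rests on those three steps alone.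

The expected change is a 1.0-fold lower number from compound 3 to compound 4 (0.01 log units; within the scatter) (an estimate). For compound 4 the estimated value is 36000 nM (estimated range 19000 nM to 65000 nM).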

Compound 4, half-maximal effective concentration: 33300 nM
The estimate for compound 4 lay 1.1-fold (0.03 log units) above the measured number, and the stated range covers the measured number.
By their numbers in this assay, from the lowest: compound 1; then compounds 4, 3 and 2 (each within the scatter of the next).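

In this assay, going from butyl to propyl on the oxygen gives a 1.1-fold lower number from compound 3 to compound 4 (0.04 log units; within the scatter), and going from isopropyl to propyl on that oxygen gives a 1.2-fold lower number from compound 2 to compound 4 (0.08 log units; within the scatter), so these three chains do not separate by length or branching. Propoxy in place of chloro gives a 2.7-fold higher number from compound 1 to compound 4 (0.43 log units; beyond the scatter), a modest step like those seen for isopropoxy and butoxy, so the three oxygen-linked chains fall together, apart from the chloro group. No measured evidence bears on this flat response or on the gap to chloro.

Open, on these data alone, is whether methoxy, a longer chain such as hexyloxy, or an amine on that aromatic carbon would stay with these chains or come closer to the chloro group. Open too, as far as these compounds go, is whether this flat response holds in cells other than these.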